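A few compounds are considered here, and "the series" means these few. Any claim that something is new, unique, unknown or untested is made for them only; others in the source may bear on it.

The measured compounds in a functional assay on K562 cells (Homo sapiens) for cytotoxicity, read by CCK-8 assay, with a stated time of 72 h; on this read-out higher numbers stand for weaker inhibition and lower numbers for stronger inhibition:
Compound 1 `C=CCn1c(=O)/c(=C\c2cccc(Cl)c2)[nH]c(=O)/c1=C\c1ccccc1OC` gives 2700 nM
Compound 2 `C=CCn1c(=O)/c(=C\c2ccccc2Cl)[nH]c(=O)/c1=C\c1ccccc1OC` gives 2500 nM
Compound 3 `C=CCn1c(=O)/c(=C\c2cccc(Br)c2)[nH]c(=O)/c1=C\c1ccccc1OC` gives 2400 nM

Compound 3 has the lowest of the three numbers in this assay, but the gaps to its neighbours are small: a 1.0-fold lower number from compound 2 to compound 3 (0.02 log units; within the scatter) and a 1.1-fold lower number from compound 1 to compound 3 (0.05 log units; within the scatter). The three compounds are therefore not separated by the measurements.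

Compound 4 `C=CCn1c(=O)/c(=C\c2ccccc2C(F)(F)F)[nH]c(=O)/c1=C\c1ccccc1OC` differs from compound 3 in one place: 2-(trifluoromethyl)phenyl in place of 3-bromophenyl on a double-bonded chain carbon bound to an aromatic carbon. Going by the values given here, two measured steps bear on this change. Moving the chloro group from the 3-chlorophenyl to the 2-chlorophenyl arrangement, a 1.1-fold lower number from compound 1 to compound 2 (0.03 log units; within the scatter), and exchanging chloro for bromo, a 1.1-fold lower number from compound 1 to compound 3 (0.05 log units; within the scatter), both stayed within the scatter. Among the compounds with values here, no measured compound carries a trifluoromethyl group, so the effect of that group itself is untested here. On the steps available, the step from compound 3 to compound 4 is expected to be small, a 1.1-fold higher number from compound 3 to compound 4 (0.03 log units; within the scatter), with no clear direction beyond the scatter. Compound 4 is thus expected to give about 2600 nM in this assay, within a range from 1200 nM to 6000 nM.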

Compound 4, half-maximal inhibitory concentration: 2700 nM
The estimate for compound 4 lay 1.0-fold (0.02 log units) below the measured number; low and high end bracket the measured number.
By their numbers in this assay, from the lowest: compounds 3, 2, 1 and 4 (each within the scatter of the next).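

In this assay, going by these compounds alone, a trifluoromethyl group appears for the first time, and 2-(trifluoromethyl)phenyl on a double-bonded chain carbon bound to an aromatic carbon leaves the number level with all three halogen-bearing compounds: a 1.1-fold higher number from compound 3 to compound 4 (0.05 log units; within the scatter), a 1.1-fold higher number from compound 2 to compound 4 (0.03 log units; within the scatter), and no change at the digits printed from compound 1 to compound 4 (within the scatter). Within the data shown here, the direct exchange of chloro for trifluoromethyl, which the earlier compounds could not address, therefore separates nothing at this place, and the four compounds remain unresolved by this measurement. No available evidence bears on why this change leaves the number within the scatter.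

Every aromatic ring shown at this place carries a halogen or a trifluoromethyl group, so it remains open whether an amine, a hydroxyl group, or a carboxylic acid on that ring would shift the number beyond the scatter. From the compounds shown here alone, whether changes elsewhere on the shared core would do so is also open.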